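The source may report more compounds than this note shows. Statements on the series, on what has been measured and on what is new or still open speak of the compounds shown alone.

Measured so far in a functional assay on HL-60 cells (Homo sapiens) for inhibition, read by MTT assay, with a stated time of 72 h; on this read-out lower numbers stand for stronger inhibition and higher numbers for weaker inhibition:
compound 1 `Cc1nc(-c2ccccc2F)c(C(=O)N2CCN(c3cccc(Cl)c3)CC2)o1` — 39.4 nM
compound 2 `Cc1nc(-c2ccc(F)cc2)c(C(=O)N2CCN(c3cccc(Cl)c3)CC2)o1` — 40.1 nM
compound 3 `COc1cccc(-c2nc(C)oc2C(=O)N2CCN(c3cccc(Cl)c3)CC2)c1` — "not active" (no number reported) (no number reported)

Compound 3 stands apart from the other two: in this assay compound 3 is recorded as "not active" (no number reported), with no half-maximal inhibitory concentration given, whereas compound 1 gives 39.4 nM and compound 2 gives 40.1 nM. Going by the values given here, the only step between measured compounds, a 1.0-fold higher number from compound 1 to compound 2 (0.01 log units; within the scatter), lies within the scatter and concerns a different change on the same ring, so it says nothing about how a substitution on the 3-methoxyphenyl of compound 3 would read.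

Compound 4 `CC(=O)Nc1cccc(-c2nc(C)oc2C(=O)N2CCN(c3cccc(Cl)c3)CC2)c1` differs from compound 3 by acetamido in place of methoxy on an aromatic carbon. Among the compounds with values here, no measured pair bears directly on this change; the reference point itself carries no number, and no step exists for the comparison of compound 3 with compound 1 or compound 2. The expectation for compound 4 therefore rests only on compound 3 being recorded as "not active" (no number reported), which places the likely outcome in this assay at weak inhibition or again no number, with a wide range.

On that basis compound 4 is estimated at 3000 nM, between 100 nM and 40000 nM, in this assay.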

Compound 4, half-maximal inhibitory concentration: 208 nM
Compound 4: the middle estimate sits 14-fold (1.16 log units) above what was measured; the range from low to high includes it.
By their numbers in this assay, from the lowest: compounds 1 and 2 (each within the scatter of the next); then compound 4.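

In this assay compound 4 gives 208 nM, so this position can carry a substituent and still return a number, whereas the 3-methoxyphenyl of compound 3 gives "not active" (no number reported). The change from methoxy to acetamido therefore separates a compound with a measured half-maximal inhibitory concentration from one without, but its size cannot be read, as compound 3 offers no number to step from. Against the two fluorophenyl compounds, 3-acetamidophenyl reads weaker, with a 5.2-fold higher number from compound 2 to compound 4 (0.71 log units; beyond the scatter) and a 5.3-fold higher number from compound 1 to compound 4 (0.72 log units; beyond the scatter), so it does not restore the level of either compound; no supporting data on hand account for the difference between acetamido and methoxy or for this remaining gap.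

The compounds shown leave open which part of the acetamido group matters, since a plain amine or a carboxylic acid in its place would separate the amide hydrogen and carbonyl from the mere presence of a larger group. As far as these compounds go, a longer acyl chain, such as propionamido, also remains open, as does whether the reading from compound 4 carries over to other substituents on this ring.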